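From hexyloxy to benzylsulfanyl on the shared core

The source may report more compounds than this note shows. Statements on the series, on what has been measured and on what is new or still open speak of the compounds shown alone.

Compound 1 `CCCSc1nc(N)nc2c1ncn2/C=C1/CC1(CO)CO`: > 20000 nM in an ADME assay on MOLT-3 cells (Homo sapiens) for cytotoxicity, with a stated time of 7 days (on this read-out higher numbers stand for lower toxicity in this test and lower numbers for higher toxicity in this test), a limit
Compound 2 `CCCCCCOc1nc(N)nc2c1ncn2/C=C1/CC1(CO)CO`: > 20000 nM in this assay, a limit

Compound 2 stands only at a limit, > 20000 nM, and has no exact number. Compound 3 `Nc1nc(SCc2ccccc2)c2ncn(/C=C3/CC3(CO)CO)c2n1` differs from it by benzylsulfanyl in place of hexyloxy on an aromatic carbon, with benzylsulfanyl in place of hexyloxy on an aromatic carbon. Among the measured compounds shown here, one measured step bears on this place: a step that the two limits leave unreadable from compound 1 to compound 2. Its size cannot be read. The evidence so far is the limit of > 20000 nM in this assay, at which 2 of the 2 values shown sit, so no step beyond the scatter is expected in this assay, in either direction. The expected step is a number no higher from compound 2 to compound 3 (the limit leaves the size open). Compound 3 is estimated at 20000 nM, within an expected range of 9000 nM to 40000 nM.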

Compound 3, half-maximal cytotoxic concentration: > 20000 nM
Compound 3 was reported as a limit; the forecaster's own chance of this, stated with the estimate: 70%; the middle value lies on the limit itself.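

In this assay compound 3 gives > 20000 nM as a limit, and the steps among compound 1, compound 2 and compound 3 cannot be read. Whether propylsulfanyl, hexyloxy and benzylsulfanyl differ at all in this assay stays open for the compounds shown.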